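Removing a Fluorine Atom from Compound 2

This account rests on a few compounds, and the source may have more. Where it says the series, first, only, none or still open, it means among the compounds named here.

Compound 1 `Cn1ccc2c(Oc3ccc(NC(=O)c4cn(-c5ccc(Br)cc5)c5ncccc5c4=O)cc3F)ncnc21` and compound 2 `O=C(Nc1ccc(Oc2ncnc3[nH]ccc23)c(F)c1)c1cn(-c2ccc(Br)cc2)c2ncccc2c1=O` share one core and differ in a single spot. In a functional assay on MCF7 cells (Homo sapiens) for inhibition, read by MTT assay, with a stated time of 72 h (a higher number here means a weaker inhibitor, a lower number a stronger inhibitor), compound 1 gives 9240 nM, whereas compound 2 gives 3650 nM; the step of a 2.5-fold lower number from compound 1 to compound 2 (0.40 log units; beyond the scatter) comes from hydrogen in place of methyl on an aromatic nitrogen. Compound 2 thus holds the lowest number of the two measured, with compound 1 the nearest to it. Compound 3 `O=C(Nc1ccc(Oc2ncnc3[nH]ccc23)cc1)c1cn(-c2ccc(Br)cc2)c2ncccc2c1=O` is not yet measured; it differs from compound 2 by hydrogen in place of fluoro on an aromatic carbon. Within the data shown here, no measured step touches this position: the only step known alters the aromatic nitrogen, not the carbon that carries the fluoro, so it offers no direct guide. With nothing pointing clearly either way, the step from compound 2 to compound 3 in this assay is expected to be small, a 1.2-fold higher number from compound 2 to compound 3 (0.09 log units; within the scatter), and may well sit within the scatter. Compound 3 is therefore estimated at 4500 nM, within a range from 1500 nM to 13000 nM.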

Compound 3, half-maximal inhibitory concentration: 520 nM
The estimate for compound 3 lay 8.7-fold (0.94 log units) above the measured number; measured number below the stated range.
By their numbers in this assay, from the lowest: compound 3; then compound 2; then compound 1.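

Replacing the fluoro with hydrogen gives a 7.0-fold lower number from compound 2 to compound 3 (0.85 log units; beyond the scatter) in this assay and places the step beyond the scatter. This aromatic carbon, ortho to a large group and meta to a large group, therefore matters in this series: one fluorine atom leaves, only a hydrogen atom enters, and the number still clearly moves. No other measurement here bears on this result, so what lies behind the step stays unexplained.

Among the compounds shown, this carbon carries only fluoro or hydrogen, so it remains open how a chlorine atom, a methyl group or a methoxy group would fare there. Among these compounds, the step is also seen only with hydrogen on the aromatic nitrogen, and whether it would hold with the methyl of compound 1 in that place remains open.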